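The source may hold more compounds than are shown below. What is called first, only, known or untested is meant among the compounds shown, and "the series" means these compounds.

Measured so far in a functional assay on HO8910 cells (Homo sapiens) for inhibition, read by MTT assay, with a stated time of 24 h, tested at 100 ug/mL; on this read-out lower numbers stand for less inhibition of growth and higher numbers for more inhibition of growth at the one concentration tested:

Compound 1 `O=C(CCCCC1CCSS1)Nc1ccccn1`: 51.9%
Compound 2 `O=C(CCCCC1CCSS1)Nc1ccc(Cl)cn1`: 68.6%
Compound 3 `CC(=O)SCCC(CCCCC(=O)Nc1ccccc1)SC(C)=O`: 22.3%

Compound 4 `CC(=O)SCCC(CCCCC(=O)Nc1ccccc1Cl)SC(C)=O` has not yet been measured in this assay. It differs from compound 3 by one change, (chloro in place of hydrogen on an aromatic carbon).

The same kind of change was made once before among these compounds, from compound 1 to compound 2, (chloro in place of hydrogen on an aromatic carbon). There it gave a number 16.7 percentage points higher from compound 1 to compound 2 (beyond the scatter). The two places are not the same word for word: in compound 2 the chloro sits on a ring with one nitrogen, two atoms from the ring nitrogen and para to a large group, whereas in compound 4 it sits on a ring of carbon only, ortho to a large group. So this is the same kind of change, not the same change. How the core of compound 3 differs from the core of compound 1 is not broken down here.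

Compound 3 starts from the lowest of the three values. Because compound 2 gained over compound 1 by a number 16.7 percentage points higher from compound 1 to compound 2 (beyond the scatter), a step of similar size, tempered by the different place, is expected for compound 4, namely a number 13.7 percentage points higher from compound 3 to compound 4 (beyond the scatter). The estimate for compound 4 in this assay is therefore 36%, between 18% and 56%.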

Compound 4, percent growth inhibition at one concentration: "not active" (no number reported)
Compound 4 has no reported number here, and the estimate cannot be compared.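

In this assay, among these compounds, compound 4 is reported only as "not active", without a number, so no step from compound 3 to compound 4 can be read. No measurement shown here offers an explanation for this result. From the compounds shown here alone, what stays open is how far, and in which direction, the chloro in place of hydrogen shifts growth inhibition on the core of compound 3.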